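The source may report more compounds than this note shows. Statements on the series, on what has been measured and on what is new or still open speak of the compounds shown alone.

In an in vitro ADME assay on microsomes from liver (Rattus norvegicus) for metabolic stability (a lower number here means slower removal, a higher number faster removal of the compound), compound 3 `Cc1cccc(N2C[C@@H](C(=O)NCc3cccc(C(F)(F)F)c3Cl)N(C)C2=O)n1` gives 6.1 mL.min-1.g-1, the highest of the three numbers available. Compound 2 `Cc1ncccc1N1C[C@@H](C(=O)NCc2cccc(C(F)(F)F)c2Cl)N(C)C1=O` gives 2.6 mL.min-1.g-1, and compound 1 `CN1CCC(N2C[C@@H](C(=O)NCc3cccc(C(F)(F)F)c3Cl)N(C)C2=O)CC1` gives 0.5 mL.min-1.g-1. The next compound, compound 4 `Cc1cc(N2C[C@@H](C(=O)NCc3cccc(C(F)(F)F)c3Cl)N(C)C2=O)ccn1`, has the same atoms as compound 3, joined differently: 2-methylpyridin-4-yl in place of 6-methylpyridin-2-yl on an amide-type nitrogen in a ring. Here 2-methylpyridin-4-yl stands in place of 6-methylpyridin-2-yl on an amide-type nitrogen in a ring. The closest evidence is the exchange of 2-methylpyridin-3-yl for 6-methylpyridin-2-yl, a 2.3-fold higher number from compound 2 to compound 3 (0.37 log units; beyond the scatter), a modest step beyond the scatter. The steps of a 5.2-fold higher number from compound 1 to compound 2 (0.72 log units; beyond the scatter) and a 12-fold higher number from compound 1 to compound 3 (1.09 log units; beyond the scatter) are larger, but both start from 1-methylpiperidin-4-yl and bear less directly on this change. Within the data shown here, with only two such aromatic compounds measured, the evidence is thin, and a modest drop in this assay is expected, since compound 3 at 6.1 mL.min-1.g-1 is the top of the series. The estimated step is a 1.7-fold lower number from compound 3 to compound 4 (0.24 log units; within the scatter). For compound 4 the expected value is 3.5 mL.min-1.g-1, within an estimated range from 1.5 mL.min-1.g-1 to 8 mL.min-1.g-1.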

Compound 4, intrinsic clearance in microsomes: 3.7 mL.min-1.g-1
For compound 4 the middle estimate is 1.1-fold (0.02 log units) below the measured one, within the range that was stated.
By their numbers in this assay, from the lowest: compound 1; then compounds 2, 4 and 3 (each within the scatter of the next, the first and the last beyond it).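

With 2-methylpyridin-4-yl on the amide-type nitrogen, this assay gives a 1.6-fold lower number from compound 3 to compound 4 (0.22 log units; within the scatter) and a 1.4-fold higher number from compound 2 to compound 4 (0.15 log units; within the scatter); compound 4 thus lies within the scatter of both other methylpyridine compounds, although compound 2 and compound 3 lie beyond the scatter of each other, so the earlier gap between those two does not extend into a clear order across all three. The separation from the saturated group also holds for this third methylpyridine, with a 7.4-fold higher number from compound 1 to compound 4 (0.87 log units; beyond the scatter). The data give no measured basis for explaining these differences.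

The compounds shown leave open whether an unsubstituted pyridine, a phenyl ring or a methoxypyridine at this nitrogen would stay with the methylpyridines. They also leave open whether a piperidine carrying no methyl group on its nitrogen would stay close to compound 1.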